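A few compounds are considered here, and "the series" means these few. Any claim that something is new, unique, unknown or untested is made for them only; others in the source may bear on it.

Measured in a functional assay on HCT-116 cells (Homo sapiens) for antiproliferative activity, read by CCK-8 assay, with a stated time of 72 h, tested at 8 uM; on this read-out lower numbers stand for a weaker effect and higher numbers for a stronger effect at the one concentration tested:

Compound 1, `CC(C)n1cnc2c(Nc3ccccc3)nc(NCOCc3ccc(/C=C/C(=O)Nc4ccccc4N)cc3)nc21`: 41.7%
Compound 2, `CCCCn1cnc2c(NCc3ccc(C(=O)Nc4ccccc4N)cc3)nc(Cl)nc21`: 40.9%
Compound 3, `CC(C)n1cnc2c(NCc3ccc(C(=O)Nc4ccccc4N)cc3)nc(Cl)nc21`: 76%

Compound 3 and compound 2 share one core and differ in a single place: butyl in place of isopropyl on an aromatic nitrogen. That change gave a number 35.1 percentage points lower from compound 3 to compound 2 (beyond the scatter). Compound 1 is built on a different core, and the difference between the two cores is not broken down here; compound 1 and compound 2 show numbers within the scatter of each other.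

Compound 4, `CCCCn1cnc2c(Nc3ccccc3)nc(NCOCc3ccc(/C=C/C(=O)Nc4ccccc4N)cc3)nc21`, has not yet been measured. It differs from compound 1 by butyl in place of isopropyl on an aromatic nitrogen, the same change at the same place as between compound 3 and compound 2. Among the measured compounds shown here, from compound 1 to compound 4 a drop is expected, estimated at a number 19.7 percentage points lower from compound 1 to compound 4 (beyond the scatter), because a number 35.1 percentage points lower from compound 3 to compound 2 (beyond the scatter), though with only one earlier example the size is uncertain. Compound 4 is expected to give about 22%, between 8% and 40%.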

Compound 4, a percentage reported as inhibition, at one concentration (the size of the read-out at that concentration, not a potency): 51.9%
Compound 4: middle estimate off by 29.9 percentage points, on the low side, outside the stated range (above it).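

In this assay, butyl in place of isopropyl on an aromatic nitrogen gave a number 10.2 percentage points higher from compound 1 to compound 4 (beyond the scatter), so on the core of compound 1 the change did not follow the earlier drop. Set side by side, the two steps differ: the same change on two cores in this assay, a number 35.1 percentage points lower (beyond the scatter) from compound 3 to compound 2 and a number 10.2 percentage points higher (beyond the scatter) from compound 1 to compound 4, 45.3 percentage points apart, beyond the scatter of two such steps In this series, then, the effect of this change cannot simply be carried from one core to another, but two pairs do not show which feature of the cores matters or predict the result on a third core.

The compounds shown leave open how a shorter chain such as ethyl or a longer one such as hexyl would behave on this nitrogen. They also leave open whether a cyclopentyl ring there would follow either core's trend.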